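A few compounds are considered here, and "the series" means these few. Any claim that something is new, unique, unknown or untested is made for them only; others in the source may bear on it.

Compound 1 `COc1ccc2c(c1)OC(c1cc(OC)c(OC)c(OC)c1)C(C(=O)OC(C)(C)C)=C2` gives 14100 nM in a functional assay for inhibition of nuclear factor NF-kappa-B complex (Homo sapiens); on this read-out lower numbers stand for stronger inhibition and higher numbers for weaker inhibition.
Compound 2 `COc1ccc2c(c1)OC(c1cc(OC)c(OC)c(OC)c1)C(C=O)=C2` gives 13500 nM.
Compound 3 `COc1ccc2c(c1)OC(c1cc(OC)c(OC)c(OC)c1)C(C#N)=C2` gives 3400 nM.

Compound 3 holds the lowest number of the three, its steps to both other compounds lying beyond the scatter: a 4.1-fold lower number from compound 1 to compound 3 (0.62 log units; beyond the scatter) and a 4.0-fold lower number from compound 2 to compound 3 (0.60 log units; beyond the scatter), while a 1.0-fold lower number from compound 1 to compound 2 (0.02 log units; within the scatter). Compound 4 `COc1ccc2c(c1)OC(c1cc(OC)c(OC)c(OC)c1)C(C(=O)N(C)OC)=C2` differs from compound 3 by methoxy(methyl)carbamoyl in place of cyano on a double-bonded ring carbon. The two steps that bear on this change both moved from a carbonyl-bearing group to cyano and gave modest gains; compound 4 brings a carbonyl-bearing group back, so a modest step in the opposite direction is expected, returning toward the numbers of compounds 1 and 2. Compound 4 is therefore estimated at 11000 nM, within 4000 nM to 30000 nM, which is expected to be a step of a 3.2-fold higher number from compound 3 to compound 4 (0.51 log units; beyond the scatter).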

Compound 4, half-maximal inhibitory concentration: 11700 nM
Compound 4: middle estimate off by 1.1-fold (0.03 log units), on the low side, within the range that was stated.
By their numbers in this assay, from the lowest: compound 3; then compounds 4, 2 and 1 (each within the scatter of the next).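

In this assay, the methoxy(methyl)carbamoyl group at this double-bonded ring carbon does not keep the lower number seen with cyano (a 3.4-fold higher number from compound 3 to compound 4 (0.54 log units; beyond the scatter)). Compound 4 instead reads alike with both earlier carbonyl-bearing compounds (a 1.2-fold lower number from compound 2 to compound 4 (0.06 log units; within the scatter); a 1.2-fold lower number from compound 1 to compound 4 (0.08 log units; within the scatter)), so hydrogen, tert-butoxy and methoxy(methyl)amino on the carbonyl carbon make no difference beyond the scatter, and only the nitrile of compound 3 stands apart. No evidence is available to explain this difference. The compounds shown leave open how a carboxylic acid, a primary amide or an aminomethyl group at this carbon would read.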